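Para substituent swaps on the aryl hydrazone: hydroxy

The compounds below may be only part of what the source reports. "The series", "measured", "known", "first", "only" and "open" are said of these compounds alone.

Compound 1 `COc1cc2c(Oc3ccc(NC(=O)N/N=C/c4ccc(C(F)(F)F)cc4)cc3F)ccnc2cc1OCCCN1CCCCC1`, compound 2 `COc1cc2c(Oc3ccc(NC(=O)N/N=C/c4ccc(OC(F)(F)F)cc4)cc3F)ccnc2cc1OCCCN1CCCCC1` and compound 3 `COc1cc2c(Oc3ccc(NC(=O)N/N=C/c4ccc(N(C)C)cc4)cc3F)ccnc2cc1OCCCN1CCCCC1` share one core and differ only in the group on the terminal aryl ring. In a functional assay on MKN-45 cells (Homo sapiens) for cytotoxicity, read by MTT assay, with a stated time of 72 h (on this read-out higher numbers stand for weaker inhibition and lower numbers for stronger inhibition), compound 1 gives 630 nM, compound 2 gives 630 nM and compound 3 gives 870 nM. The three numbers sit together: no change at the digits printed from compound 1 to compound 2 (within the scatter), a 1.4-fold higher number from compound 1 to compound 3 (0.14 log units; within the scatter) and a 1.4-fold higher number from compound 2 to compound 3 (0.14 log units; within the scatter), so compound 3 cannot be set apart from the other two.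

Compound 4 `COc1cc2c(Oc3ccc(NC(=O)N/N=C/c4ccc(O)cc4)cc3F)ccnc2cc1OCCCN1CCCCC1` carries the change (hydroxy in place of dimethylamino on an aromatic carbon). Going by the values given here, no measured step involves a hydroxy group, so the only bearing comes from the exchanges at the same position among compounds 1, 2 and 3, which were a 1.4-fold higher number from compound 1 to compound 3 (0.14 log units; within the scatter) and a 1.4-fold higher number from compound 2 to compound 3 (0.14 log units; within the scatter), both within the scatter. Taken together they suggest that this position tolerates exchange without a step beyond the scatter in this assay.

Compound 4 is therefore expected to land near compound 3, with an estimated step of a 1.1-fold lower number from compound 3 to compound 4 (0.04 log units; within the scatter). The estimate for compound 4 is 800 nM, with a range of 400 nM to 1600 nM.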

Compound 4, half-maximal inhibitory concentration: 850 nM
The estimate for compound 4 lay 1.1-fold (0.03 log units) below the measured number, and the stated range covers the measured number.
By their numbers in this assay, from the lowest: compounds 1, 2, 4 and 3 (each within the scatter of the next).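

In this assay the step of a 1.0-fold lower number from compound 3 to compound 4 (0.01 log units; within the scatter) shows that hydroxy can stand in place of dimethylamino on this aromatic carbon, para to a large group, with no step beyond the scatter. The steps of a 1.3-fold higher number from compound 2 to compound 4 (0.13 log units; within the scatter) and a 1.3-fold higher number from compound 1 to compound 4 (0.13 log units; within the scatter) show the same against trifluoromethoxy and trifluoromethyl, so all four compounds now sit within the scatter of one another. The earlier compounds shown here carried no hydrogen-bond donor at this place, so the tolerance seen among them now reaches a group that has one. No data at hand explain this flat picture.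

Going by these compounds, whether a carboxylic acid, a primary amine or a longer chain such as butoxy would also stay within the scatter at this place remains open. Also open, on these data alone, is whether the same flat picture would hold in a read-out other than this one.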